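Imidazole amide within a series of tolerated compounds

A few compounds are considered here, and "the series" means these few. Any claim that something is new, unique, unknown or untested is made for them only; others in the source may bear on it.

Measured compounds:
compound 1, `COc1ccc(-c2cnc(NC(=O)c3ccccn3)n2C)cc1`: > 100000 nM
compound 2, `COc1ccc(-c2cnc(NC(=O)c3ccccc3Br)n2C)cc1`: > 100000 nM
compound 3, `COc1ccc(-c2cnc(NC(=O)c3ccc(C#N)cc3)n2C)cc1`: > 100000 nM

In a toxicity assay on THP-1 cells (Homo sapiens) for inhibition (a lower number here means that less compound is tolerated, a higher number that more compound is tolerated), compound 1 reaches only the limit of the assay, > 100000 nM. Compound 2 likewise sits at a limit, > 100000 nM. Compound 3 again gives only a limit, > 100000 nM. Because (the limit of > 100000 nM in this assay, at which 3 of the 3 values shown sit), every value shown is a limit and compound 3 cannot be placed relative to its neighbours. The steps a step that the two limits leave unreadable from compound 1 to compound 2, a step that the two limits leave unreadable from compound 1 to compound 3 and a step that the two limits leave unreadable from compound 2 to compound 3 therefore carry no readable size.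

Compound 4, `COc1ccc(-c2cnc(NC(=O)c3ncc[nH]3)n2C)cc1`, is the compound to be measured; its change from compound 3 is 1H-imidazol-2-yl in place of 4-cyanophenyl on a carbonyl carbon. Within the data shown here, no measured step bears on this change with a readable size, so the only guide is that all three compounds with varied groups on the carbonyl carbon remain at the limit. For compound 4 the expected step is a number no higher from compound 3 to compound 4 (the limit leaves the size open), that is, none beyond the scatter. Compound 4 is expected to give 100000 nM, with a range from 50000 nM to 200000 nM, most probably again as a limit.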

Compound 4, half-maximal cytotoxic concentration: > 100000 nM
Compound 4: a limit, no number; the forecaster's own chance of this, stated with the estimate: 85%; the middle value sits exactly at the limit.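

In this assay compound 4 gives only a limit, > 100000 nM. Its steps from compound 1, compound 2 and compound 3 therefore cannot be read: the limit of > 100000 nM in this assay, at which 4 of the 4 values shown sit. The compounds shown leave open whether any of these groups on the carbonyl carbon changes the concentration tolerated.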